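This account rests on a few compounds, and the source may have more. Where it says the series, first, only, none or still open, it means among the compounds named here.

Measured in an assay on isolated protein for agonist activity at Bile acid receptor (Homo sapiens), read by AlphaScreen, with a stated time of 30 min; a lower number here means a smaller maximal response, a higher number a larger maximal response:
compound 1 `Cc1ccccc1-n1nc(C)c2c1NC(=O)[C@H](C)S[C@@H]2c1ccc(-c2ccoc2)cc1`: 40%
compound 2 `Cc1nn(-c2ccccc2Cl)c2c1C(c1ccc(Oc3ccccc3)cc1)SC(C)C(=O)N2`: 57%
compound 3 `Cc1nn(-c2ccccc2C(F)(F)F)c2c1C(c1ccc(Oc3ccccc3)cc1)SC(C)C(=O)N2`: 50%

Compound 1 stands below compound 2 by more than the usual scatter, while its gap to compound 3 lies within the scatter. Compound 4 `COc1ccc(Oc2ccc([C@H]3S[C@@H](C)C(=O)Nc4c3c(C)nn4-c3ccccc3C)cc2)cc1` is not yet measured. It differs from compound 1 by 4-methoxyphenoxy in place of furan-3-yl on an aromatic carbon. Among the compounds with values here, the only single-point step in the set, a number 7 percentage points lower from compound 2 to compound 3 (within the scatter), concerns the aryl on the shared core rather than the changed position and does not bear on this change. Compounds 2 and 3 both carry a phenoxy group at the changed position and both give higher numbers than compound 1, which is the only pointer available. A modest rise in this assay is therefore expected for compound 4, a number 12 percentage points higher from compound 1 to compound 4 (beyond the scatter). The estimate for compound 4 is 52%, with a range of 38% to 66%.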

Compound 4, largest response reached (reported as efficacy), in percent of the reference or control that the assay uses: 70%
Compound 4: middle estimate off by 18 percentage points, on the low side; the measured number lies above the stated range.
By their numbers in this assay, from the lowest: compounds 1, 3 and 2 (each within the scatter of the next, the first and the last beyond it); then compound 4.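

In this assay, 4-methoxyphenoxy in place of furan-3-yl on the aromatic carbon gives a number 30 percentage points higher from compound 1 to compound 4 (beyond the scatter). Within the data shown here, this is the first single-place reading at this position, and it shows that the maximal response depends on the group held here; the earlier step concerned only the aryl on the shared core. No measurement on hand accounts for the gain.

The change replaces the ring and adds an ether oxygen and a methoxy together, so the part responsible remains unresolved. On these data alone, whether an amine or a carboxylic acid at this position would keep the response also remains open.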